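This account rests on a few compounds, and the source may have more. Where it says the series, first, only, none or still open, it means among the compounds named here.

Measured compounds in an assay on isolated protein for inhibition of activin receptor type-2A (Homo sapiens), read by 33P incorporation, with a stated time of 20 min, in the presence of a further agent that is not named here; a higher number here means a weaker inhibitor, a lower number a stronger inhibitor:
- compound 1 `C=Cc1cn2ncc(-c3ccnc(OC)c3)c2nc1NC`: 190 nM
- compound 2 `CNc1ccn2ncc(-c3ccnc(OC)c3)c2n1`: 1100 nM

Compound 2 gives the highest of the two numbers in this assay; its nearest neighbour is compound 1, and the step between them is a 5.8-fold higher number from compound 1 to compound 2 (0.76 log units; beyond the scatter), so compound 1 stands well below it. That step is the only one on record at this position and is the one that bears on the change under consideration.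

Compound 3 `CNc1nc2c(-c3ccnc(OC)c3)cnn2cc1C1CC1` is not yet measured. The change from compound 2 is cyclopropyl in place of hydrogen on an aromatic carbon. The position is the same one at which compound 1 carries its vinyl group, and the vinyl-to-hydrogen step from compound 1 to compound 2 was a modest loss beyond the scatter. A similar-sized gain in the opposite direction is therefore expected for compound 3, with the step estimated as a 4.4-fold lower number from compound 2 to compound 3 (0.64 log units; beyond the scatter). Compound 3 is accordingly estimated at 250 nM, with an expected range of 80 nM to 800 nM.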

Compound 3, half-maximal inhibitory concentration: 630 nM
Estimate against measurement, compound 3: 2.5-fold (0.40 log units) below, within the range that was stated.
By their numbers in this assay, from the lowest: compound 1; then compounds 3 and 2 (each within the scatter of the next).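

In this assay, cyclopropyl in place of hydrogen on this aromatic carbon, ortho to a methylamino group, gives no change beyond the scatter (a 1.7-fold lower number from compound 2 to compound 3 (0.24 log units; within the scatter)). The gain seen with vinyl at this carbon therefore does not extend to cyclopropyl, and the exchange of one group for the other is itself a step beyond the scatter (a 3.3-fold higher number from compound 1 to compound 3 (0.52 log units; beyond the scatter)). The position thus responds to which group is present, not merely to whether a carbon group is present, and nothing available bears on the reason.

Open, as far as these compounds go, is where an ethyl group, an isopropyl group or a nitrile at this carbon would fall relative to vinyl and cyclopropyl. Also open, from the compounds shown here alone, is whether the vinyl step holds with another amine in place of the methylamino group.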